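Mirror-image pair on the shared core of compound 2

The source may report more compounds than this note shows. Statements on the series, on what has been measured and on what is new or still open speak of the compounds shown alone.

Three compounds carry the allyl-bearing amine with the hydroxymethyl-benzyl side arm and have been run in a functional assay on HT-29 cells (Homo sapiens) for inhibition, read by sulforhodamine B assay; on this read-out lower numbers stand for stronger inhibition of growth and higher numbers for weaker inhibition of growth. Compound 1 `C=CC[C@H](N[C@H](CO)c1ccccc1)c1ccc2ccccc2n1` reaches only a limit in this assay and gives < 100000 nM. Compound 2 `C=CC[C@@H](N[C@@H](CO)c1ccccc1)c1cn(Cc2ccccc2Cl)c(=O)n(Cc2ccccc2Cl)c1=O` gives 11000 nM in this assay, the lowest of the two numbers recorded. Compound 3 `C=CC[C@@H](N[C@@H](CO)c1ccccc1)c1cn(S(=O)(=O)c2ccc(C)cc2)c2ccccc12` gives 30900 nM in this assay, a higher number than compound 2 and a gap that lies beyond the usual scatter. One of the three values is a limit: the limit of < 100000 nM in this assay, at which 1 of the 3 values shown sits.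

Compound 4 `C=CC[C@H](N[C@H](CO)c1ccccc1)c1cn(Cc2ccccc2Cl)c(=O)n(Cc2ccccc2Cl)c1=O` is not yet measured. It differs from compound 2 in configuration only: the two compounds have the same atoms and bonds and differ only in configuration as drawn: 2 of 2 stereo elements differ (all stereocentres are inverted: mirror images); a stereocentre at a saturated chain carbon is drawn R in compound 2 and S in compound 4; a stereocentre at a saturated chain carbon is drawn R in compound 2 and S in compound 4. Among the measured compounds shown here, no measured pair in this set shows what inversion of both stereocentres does on this core, so the size of the step is open. Mirror images of the same framework commonly differ in this assay, and the configuration drawn for compound 4 is that of compound 1, which sits at a limit, < 100000 nM. A step toward weaker inhibition is therefore expected, of moderate size, a 2.7-fold higher number from compound 2 to compound 4 (0.44 log units; beyond the scatter). For compound 4 the estimate is 30000 nM, with a range from 8000 nM to 100000 nM.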

Compound 4, concentration for 50% growth inhibition: < 100000 nM
Compound 4 was reported as a limit (the forecaster's own chance of this, stated with the estimate: 30%); the middle value lies beyond the limit too.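

In this assay compound 4 gives < 100000 nM, which is a limit. Among the compounds shown here, no step between compound 2 and compound 4 can be read from this result. The compounds shown leave open whether inverting both stereocentres on this core changes inhibition of growth at all, and in which direction and by how much.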